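Working notes: from compound 2 to compound 3

A few compounds are considered here, and "the series" means these few. Any claim that something is new, unique, unknown or untested is made for them only; others in the source may bear on it.

In an ADME assay on SK-MEL cells (Homo sapiens) for cytotoxicity, read by neutral red uptake, with a stated time of 48 h (on this read-out lower numbers stand for stronger inhibition and higher numbers for weaker inhibition), compound 1 (`O=c1sc2ccccc2n1CCCCCCN1CCN(CCn2c(=O)sc3ccccc32)CC1`) gives 25000 nM and compound 2 (`O=c1sc2ccccc2n1CCCCCN1CCN(CCCn2c(=O)sc3ccccc32)CC1`) gives 16800 nM. These values lie within the usual scatter of each other, so compound 2 stands level with compound 1 on the numbers shown.

Compound 3 (`O=c1sc2ccccc2n1CCCCCCN1CCN(CCCn2c(=O)sc3ccccc32)CC1`) has not yet been measured in this assay. Its difference from compound 2 is a group of 11 heavy atoms (8 carbon, 1 nitrogen, 1 oxygen, 1 sulfur; one five-membered aromatic ring with 2 hetero atoms, one six-membered aromatic ring of carbon only) in place of a group of 10 heavy atoms (7 carbon, 1 nitrogen, 1 oxygen, 1 sulfur; one five-membered aromatic ring with 2 hetero atoms, one six-membered aromatic ring of carbon only), on a saturated chain carbon, five bonds along the chain from an amine nitrogen in a ring, on a saturated chain carbon, five bonds along the chain from an amine nitrogen in a ring. The leaving and entering groups each hold one five-membered aromatic ring with 2 hetero atoms and one six-membered aromatic ring of carbon only.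

For the measured compounds named here, no measured pair shows this change on its own, so no direct step is available. With compound 1 at 25000 nM and compound 2 at 16800 nM, no shift beyond the scatter is expected in this assay, and neither direction is favoured. The expected 1.1-fold higher number from compound 2 to compound 3 (0.03 log units; within the scatter) stays within the scatter. Compound 3 is estimated at 18000 nM, with an expected range from 9000 nM to 36000 nM.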

Compound 3, half-maximal inhibitory concentration: 12000 nM
The estimate for compound 3 lay 1.5-fold (0.18 log units) above the measured number; measured number inside the range.
By their numbers in this assay, from the lowest: compounds 3, 2 and 1 (each within the scatter of the next, the first and the last beyond it).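

In this assay, a group of 11 heavy atoms in place of a group of 10 heavy atoms, on a saturated chain carbon, five bonds along the chain from an amine nitrogen in a ring, gives a 1.4-fold lower number from compound 2 to compound 3 (0.15 log units; within the scatter) and so leaves the number level with that of compound 2. For the compounds shown here, the same kind of exchange, on a saturated chain carbon, two bonds along the chain from an amine nitrogen in a ring, gives a 2.1-fold lower number from compound 1 to compound 3 (0.32 log units; beyond the scatter) as the only step so far to pass the scatter, and it is a modest one. Nothing measured on these compounds accounts for either step.

As far as these compounds go, three compounds give no trend, so it remains open whether the number keeps falling with a longer chain on either side of the ring amine or whether the modest step is the whole of the effect. Also open, from the compounds shown here alone, is how the number responds to a different kind of group on the chain, such as an ether oxygen or an amide, in place of plain saturated carbon.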